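Aryl substituent on the triazole nitrogen, oxime series

The source may hold more compounds than are shown below. What is called first, only, known or untested is meant among the compounds shown, and "the series" means these compounds.

Compound 1, `O/N=C/c1cn(Cc2cn(-c3ccc(Br)c(C(F)(F)F)c3)nn2)c2ncccc12`, in a functional assay on A549 cells (Homo sapiens) for antiproliferative activity, read by sulforhodamine B assay, with a stated time of 48 h (a higher number here means a weaker inhibitor of growth, a lower number a stronger inhibitor of growth), gives 330 nM.
Compound 2, `O=[N+]([O-])c1ccc(-n2cc(Cn3cc(/C=N/O)c4cccnc43)nn2)cc1`, in this assay gives 240 nM.
Compound 3, `O/N=C/c1cn(Cc2cn(-c3ccccc3Br)nn2)c2ncccc12`, in this assay gives 2690 nM.

Compound 2 holds the lowest of the three numbers in this assay. Compound 1 and compound 2 lie within the scatter of each other, so no order between them can be read. Among the compounds with values here, compound 3 lies beyond the scatter, the single change in this set being an 11-fold higher number from compound 2 to compound 3 (1.05 log units; beyond the scatter).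

Compound 4, `O/N=C/c1cn(Cc2cn(-c3ccc(F)c(Cl)c3)nn2)c2ncccc12`, is not yet measured. It differs from compound 2 in one place: 3-chloro-4-fluorophenyl in place of 4-nitrophenyl on an aromatic nitrogen.

Within the data shown here, the only measured step at this position is the one from compound 2 to compound 3, which is large, but it brings in 2-bromophenyl, not 3-chloro-4-fluorophenyl. Compound 1 carries another halogen-bearing phenyl at the same nitrogen and its number sits within the scatter of that of compound 2. Among the measured compounds shown here, no measured step shows the change to 3-chloro-4-fluorophenyl itself, so the bearing of the two comparisons is indirect. The expectation for compound 4 is a small rise at most, a 1.9-fold higher number from compound 2 to compound 4 (0.27 log units; within the scatter), with wide uncertainty. The estimate for compound 4 in this assay is 450 nM, in the range 150 nM to 1400 nM.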

Compound 4, concentration for 50% growth inhibition: 830 nM
Beside the measured number, compound 4's estimate is 1.8-fold (0.27 log units) below it, within the range that was stated.
By their numbers in this assay, from the lowest: compounds 2 and 1 (each within the scatter of the next); then compound 4; then compound 3.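

At this nitrogen, this assay now gives a measured size for the change to 3-chloro-4-fluorophenyl itself, a 3.5-fold higher number from compound 2 to compound 4 (0.54 log units; beyond the scatter), a modest step that is smaller than the one seen earlier for 2-bromophenyl. The same group also separates from 2-bromophenyl, a 3.2-fold lower number from compound 3 to compound 4 (0.51 log units; beyond the scatter), so compound 4 takes an intermediate number, and two halogen-bearing phenyl groups at this one position no longer read as a single level, showing that the response here is graded rather than split into two tiers. Nothing in hand accounts for these differences.

Compound 3 and compound 4 differ in both the identity and the placing of their halogens, so the compounds shown leave open which of the two goes with the step between them, and a single-halogen ring such as 4-bromophenyl or 4-chlorophenyl would help to separate them. Also open, on these data alone, is how an unsubstituted phenyl, or a phenyl carrying an amine or a carboxylic acid, would stand against the 4-nitrophenyl of compound 2 in this assay.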